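Extending the Ring Amine Substituent from Methyl to Ethyl

A few compounds are considered here, and "the series" means these few. Any claim that something is new, unique, unknown or untested is made for them only; others in the source may bear on it.

Measured compounds:
- compound 1, `CN1CCC(n2cc(S(=O)(=O)c3cccc4ccccc34)c3ccccc32)C1`: 6 nM
- compound 2, `COc1ccc2c(c1)c(S(=O)(=O)c1cccc(F)c1)cn2C1CCCNC1`: 10.7 nM
- compound 3, `COc1ccc2c(c1)c(S(=O)(=O)c1cccc(F)c1)cn2C1CCCN(C)C1`: 68 nM

In an assay on HeLa cells for displacement of a labelled ligand from 5-hydroxytryptamine receptor 6 (Homo sapiens), with a stated time of 2 h (on this read-out higher numbers stand for weaker inhibition and lower numbers for stronger inhibition), compound 1 gives 6 nM, compound 2 gives 10.7 nM and compound 3 gives 68 nM. Compound 3 therefore has the highest number of the three, standing beyond the scatter from both compound 2 and compound 1, so it is the weakest of the measured set in this assay. Going by the values given here, the one step between neighbours in this set, a 6.4-fold higher number from compound 2 to compound 3 (0.80 log units; beyond the scatter), is a modest weakening on introduction of the methyl on the ring amine nitrogen.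

Compound 4, `CCN1CCCC(n2cc(S(=O)(=O)c3cccc(F)c3)c3cc(OC)ccc32)C1`, differs from compound 3 by methyl in place of hydrogen on a saturated chain carbon bound to an amine nitrogen in a ring. Among the compounds with values here, no measured step covers this particular change; the only step available, from compound 2 to compound 3, concerns the substituent on the nitrogen itself rather than its extension. Within the data shown here, with no direct precedent, the lengthening of methyl to ethyl is expected to bring at most a small shift in this assay, most likely not beyond the scatter, with a slight lean toward a weaker value given that the direction of a 6.4-fold higher number from compound 2 to compound 3 (0.80 log units; beyond the scatter) was toward weaker binding. Compound 4 is thus estimated at 85 nM, in a range of 30 nM to 250 nM, corresponding to an expected step of a 1.3-fold higher number from compound 3 to compound 4 (0.10 log units; within the scatter).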

Compound 4, inhibition constant: 16 nM
The estimate for compound 4 lay 5.3-fold (0.73 log units) above the measured number, and the stated range ends above it.
By their numbers in this assay, from the lowest: compounds 1, 2 and 4 (each within the scatter of the next, the first and the last beyond it); then compound 3.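

In this assay, the substituent on the ring amine nitrogen does not act in one direction: methyl in place of hydrogen had given a 6.4-fold higher number from compound 2 to compound 3 (0.80 log units; beyond the scatter), yet extending that methyl to ethyl gives a 4.3-fold lower number from compound 3 to compound 4 (0.63 log units; beyond the scatter), so the change from 1-methylpiperidin-3-yl to 1-ethylpiperidin-3-yl reverses the earlier weakening. Set against the unsubstituted amine, the ethyl compound shows a 1.5-fold higher number from compound 2 to compound 4 (0.17 log units; within the scatter), which means that hydrogen and ethyl on this nitrogen cannot be told apart here, and among these three compounds only the methyl compound, compound 3, stands apart from the other two. Nothing available accounts for this non-linear run from hydrogen through methyl to ethyl, and no independent measurement bears on it.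

The compounds shown leave open whether a longer chain such as propyl, a branched isopropyl or a benzyl group on the same nitrogen would stay level with ethyl or move away from it. They also leave open whether the same run of hydrogen, methyl and ethyl would hold on the core of compound 1, which carries a methyl on its ring amine.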